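The source may hold more compounds than are shown below. What is called first, only, known or untested is meant among the compounds shown, and "the series" means these compounds.

Measured so far in a functional assay on PC-3 cells (Homo sapiens) for inhibition; on this read-out higher numbers stand for weaker inhibition and lower numbers for stronger inhibition: compound 1 `COc1cc2nc(N3CCN(S(=O)(=O)c4ccc(I)cc4)CC3)nc(N)c2cc1OC` gives 15000 nM, compound 2 `COc1cc2nc(N3CCN(S(=O)(=O)c4ccc([N+](=O)[O-])cc4)CC3)nc(N)c2cc1OC` gives 36000 nM, and compound 3 `COc1cc2nc(N3CCN(S(=O)(=O)c4cccc(C(=O)O)c4)CC3)nc(N)c2cc1OC` gives 53000 nM.

Compound 3 has the highest of the three numbers; its gap to compound 2 lies within the scatter, while a 3.5-fold higher number from compound 1 to compound 3 (0.55 log units; beyond the scatter) lies beyond it. Compound 4 `COc1cc2nc(N3CCN(S(=O)(=O)c4ccc(N)cc4N)CC3)nc(N)c2cc1OC` differs from compound 3 by 2,4-diaminophenyl in place of 3-carboxyphenyl on a sulfonyl sulfur. Among the compounds with values here, the steps that bear on this change are the two earlier exchanges on the sulfonyl sulfur: a 3.5-fold higher number from compound 1 to compound 3 (0.55 log units; beyond the scatter) and a 1.5-fold higher number from compound 2 to compound 3 (0.17 log units; within the scatter), both modest. A change of similar size is therefore expected for compound 4, likely toward a lower number, as compound 3 carries the highest of the three. Compound 4 is estimated at 30000 nM in this assay, within 10000 nM to 90000 nM, a step of a 1.8-fold lower number from compound 3 to compound 4 (0.25 log units; within the scatter).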

Compound 4, half-maximal inhibitory concentration: 67000 nM
Compound 4: middle estimate off by 2.2-fold (0.35 log units), on the low side; the range from low to high includes it.
By their numbers in this assay, from the lowest: compound 1; then compounds 2, 3 and 4 (each within the scatter of the next).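

In this assay the 2,4-diaminophenyl group on the sulfonyl sulfur does not separate compound 4 from the compounds carrying 3-carboxyphenyl (a 1.3-fold higher number from compound 3 to compound 4 (0.10 log units; within the scatter)) or 4-nitrophenyl (a 1.9-fold higher number from compound 2 to compound 4 (0.27 log units; within the scatter)). Within the data shown here, the only step here beyond the scatter is the one to the 4-iodophenyl group (a 4.5-fold higher number from compound 1 to compound 4 (0.65 log units; beyond the scatter)), so compound 1 stands apart from the other three. Nothing measured here explains this.

The compounds shown leave open whether a 4-bromophenyl or 4-chlorophenyl group would match compound 1. They also leave open what an open alkyl chain on the sulfonyl sulfur would give.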